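Three esters level in one mouse read-out

The compounds below may be only part of what the source reports. "The series", "measured", "known", "first", "only" and "open" are said of these compounds alone.

Compound 1 `COc1cc(OC)c(OC)cc1/C=C/COC(=O)/C=C/c1ccc(OC)c(OC)c1` carries the shared core and in a functional assay on the whole organism (strain Kunming) with Mus musculus as the target, with a stated time of 0.5 h, at a dose of 300 mg/kg by the intraperitoneal route (on this read-out higher numbers stand for a weaker effect at the one dose given and lower numbers for a stronger effect), gives 100%. Compound 2 `COc1cc(OC)c(OC)cc1/C=C/COC(=O)/C=C/c1ccc(Br)cc1` gives 100% and compound 3 `COc1cc(OC)c(OC)cc1/C=C/COC(=O)/C=C/c1ccccc1C(F)(F)F` gives 100%; compound 1 stands level with both, the step of no change at the digits printed from compound 1 to compound 2 (within the scatter) and the step of no change at the digits printed from compound 1 to compound 3 (within the scatter) both falling within the scatter, as does the step of no change at the digits printed from compound 2 to compound 3 (within the scatter) between them.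

Compound 4 `COc1cc(OC)c(OC)cc1/C=C/COC(=O)/C=C/c1cc(OC)c(OC)c(OC)c1` is not yet measured. It differs from compound 1 by methoxy in place of hydrogen on an aromatic carbon, the new group sitting ortho to a methoxy group and meta to a methoxy group on the same ring. Within the data shown here, no measured step swaps a hydrogen for a methoxy on this ring; the three steps above, all replacing the whole ring, bear only loosely on it, and each of them left the read-out unchanged.

Compound 4 is therefore expected to sit level with compound 1, an expected step of no change at the digits printed from compound 1 to compound 4 (within the scatter). The estimate for compound 4 is 100%, expected between 88% and 100%.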

Compound 4, a percentage reported as activity, at one dose (the size of the read-out at that dose, not a potency): 100%
For compound 4 middle estimate and measured number coincide at the digits printed; the measured number falls inside the stated range.
By their numbers in this assay, from the lowest: compounds 1, 2, 3 and 4 (each within the scatter of the next).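

In this assay the step of no change at the digits printed from compound 1 to compound 4 (within the scatter) comes from methoxy in place of hydrogen on an aromatic carbon, ortho to a methoxy group and meta to a methoxy group. The earlier steps shown here replaced the whole ring, whereas this one keeps the ring and adds a single group to it, so the level reading now also covers one added methoxy at this position. Nothing on hand offers an explanation for this flat result.

All four compounds print the same value, so this read-out at its one dose does not yet separate any change made on this ring. From the compounds shown here alone, whether an amine or a carboxylic acid at this position, or a longer chain in place of the methoxy, would move the number in this assay remains open.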